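Phenoxy-tail substituent swap: chloro to methoxy, cytotoxicity

A few compounds are considered here, and "the series" means these few. Any claim that something is new, unique, unknown or untested is made for them only; others in the source may bear on it.

Compound 1 `NC(=S)Nc1cccc(OCCCCCOc2ccccc2)c1` gives > 50000 nM in an ADME assay on Ava5 cells (Homo sapiens) for cytotoxicity (on this read-out lower numbers stand for higher toxicity in this test and higher numbers for lower toxicity in this test), which is a limit of the assay and not a number.
Compound 2 `NC(=S)Nc1cccc(OCCCCCOc2ccc(F)cc2)c1` gives 5000 nM in this assay.
Compound 3 `NC(=S)Nc1cccc(OCCCCCOc2ccc(Cl)cc2)c1` gives 7000 nM in this assay.

Compound 3 stands highest of the two numbers, with compound 2 within the scatter of it. Compound 1 sits at the limit (the limit of > 50000 nM in this assay, at which 1 of the 3 values shown sits). Compound 4 `COc1ccc(OCCCCCOc2cccc(NC(N)=S)c2)cc1` differs from compound 3 by methoxy in place of chloro on an aromatic carbon. Going by the values given here, no measured pair covers methoxy in place of chloro. Among the compounds with values here, the steps that bear on it are an at least 7.1-fold lower number from compound 1 to compound 3 (0.85 log units; beyond the scatter) and an at least 10-fold lower number from compound 1 to compound 2 (1.00 log units; beyond the scatter), both halogen for hydrogen and both lowering the number, while a 1.4-fold higher number from compound 2 to compound 3 (0.15 log units; within the scatter) is within the scatter. Methoxy is neither hydrogen nor halogen, so the direction is open; the two halogen analogues, compound 2 and compound 3, lie below the limit of compound 1, and a substituent of a different kind is expected to fall between those numbers and that limit, giving an expected step of a 2.1-fold higher number from compound 3 to compound 4 (0.33 log units; beyond the scatter). Compound 4 is estimated at 15000 nM, expected between 5000 nM and 50000 nM.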

Compound 4, half-maximal cytotoxic concentration: > 50000 nM
Compound 4: no number, only a limit; the forecaster's own chance of this, stated with the estimate: 30%; middle value at least 3.3-fold (0.52 log units) away from the limit.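

On the aromatic carbon para to a large group, the halogens now stand apart from methoxy in this assay: methoxy in place of chloro gives an at least 7.1-fold higher number from compound 3 to compound 4 (0.85 log units; beyond the scatter), and methoxy in place of fluoro gives an at least 10-fold higher number from compound 2 to compound 4 (1.00 log units; beyond the scatter). A substituent at this position is therefore not enough on its own to lower the number, since of the three substituents shown only fluoro in compound 2 and chloro in compound 3 do so, while methoxy in compound 4 does not. The step between compound 1 and compound 4 cannot be read, as each of these compounds gives a limit of the assay and not a number: the limit of > 50000 nM in this assay, at which 2 of the 4 values shown sit.

From the compounds shown here alone, whether the lower number extends beyond halogens, for instance to a trifluoromethyl group or an amine at this position, remains open. Also open, going by these compounds, is how bromo compares with fluoro and chloro here.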